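This account rests on a few compounds, and the source may have more. Where it says the series, first, only, none or still open, it means among the compounds named here.

Within the data shown here, compound 2 `CC(C)C(c1ccc(-c2ccc3cccc(F)c3c2)[nH]c1=O)N1CCCCC1=O` gives 40 nM in a functional assay on CHO cells for antagonist activity at prostaglandin E2 receptor EP3 subtype (Homo sapiens), read by cAMP accumulation; on this read-out higher numbers stand for weaker inhibition and lower numbers for stronger inhibition; compound 1 `CC(C)C(Cc1ncc[nH]1)c1ccc(-c2ccc3cccc(F)c3c2)[nH]c1=O` gives 76 nM, and the step of a 1.9-fold lower number from compound 1 to compound 2 (0.28 log units; within the scatter) lies within the scatter, so no measured compound separates from compound 2 beyond the scatter. Compound 3 `CC(C)C(c1nnc[nH]1)c1ccc(-c2ccc3cccc(F)c3c2)[nH]c1=O` carries 4H-1,2,4-triazol-3-yl in place of 2-oxopiperidin-1-yl on a saturated chain carbon bound to an aromatic carbon and a saturated chain carbon. Among the measured compounds shown here, only the step from compound 1 to compound 2 concerns this position, and it was small; the entering group resembles the (1H-imidazol-2-yl)methyl of compound 1 more than the 2-oxopiperidin-1-yl it replaces, so no step beyond the scatter is expected in this assay. For compound 3 the expected value is 80 nM (range 30 nM to 220 nM), an expected step of a 2.0-fold higher number from compound 2 to compound 3 (0.30 log units; within the scatter).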

Compound 3, half-maximal inhibitory concentration: 21 nM
Compound 3: middle estimate off by 3.8-fold (0.58 log units), on the high side; measured number outside the range, below it.
By their numbers in this assay, from the lowest: compounds 3, 2 and 1 (each within the scatter of the next, the first and the last beyond it).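

In this assay, among these compounds, the 4H-1,2,4-triazol-3-yl gives the first step at this saturated chain carbon that clears the scatter, a 3.6-fold lower number from compound 1 to compound 3 (0.56 log units; beyond the scatter), with (1H-imidazol-2-yl)methyl leaving. Against 2-oxopiperidin-1-yl the same group gives a 1.9-fold lower number from compound 2 to compound 3 (0.28 log units; within the scatter), which does not separate the two, so both the five-membered aromatic ring and the six-membered non-aromatic ring are accepted at this carbon. No evidence on hand explains either step. Compound 1 and compound 3 differ in both ring and methylene link, so open is whether a 1H-imidazol-2-yl bound directly to this carbon would match compound 3. From the compounds shown here alone, a carboxylic acid at this carbon also remains open.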